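Bromo in place of chloro in a small triazole series

The compounds below may be only part of what the source reports. "The series", "measured", "known", "first", "only" and "open" are said of these compounds alone.

Measured compounds, in an ADME assay on A549 cells (Homo sapiens) for inhibition, read by MTT assay, with a stated time of 48 h; on this read-out lower numbers stand for stronger inhibition of growth and higher numbers for weaker inhibition of growth:
- compound 1, `Clc1ccc(Cn2cc(COc3ccccc3)nn2)cc1`: a limit of the assay, > 100 ug/mL
- compound 2, `Brc1ccc(Cn2cc(COc3ccccc3)nn2)cc1`: a limit of the assay, > 100 ug/mL
- compound 3, `Clc1ccc(Cn2cc(COc3c(Cl)cc(Cl)cc3Cl)nn2)cc1`: a limit of the assay, > 100 ug/mL

Compound 2 differs from compound 1 by bromo in place of chloro on an aromatic carbon. In this assay this gave a step that the two limits leave unreadable from compound 1 to compound 2, unreadable because every value sits at the limit of > 100 ug/mL in this assay, at which 3 of the 3 values shown sit. The difference between the core of compound 1 and the core of compound 3 is not broken down here. Compound 4, `Clc1cc(Cl)c(OCc2cn(Cc3ccc(Br)cc3)nn2)c(Cl)c1`, is not yet measured; it differs from compound 3 by bromo in place of chloro on an aromatic carbon, the same change, at the same place. Given that the step that the two limits leave unreadable from compound 1 to compound 2 stayed unreadable, the expected step in this assay is a number no higher from compound 3 to compound 4 (the limit leaves the size open), and compound 4 is expected to give 100 ug/mL, most likely again only a limit, between 50 ug/mL and 200 ug/mL.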

Compound 4, concentration for 50% growth inhibition: > 100 ug/mL
Compound 4 was reported as a limit; the forecaster's own chance of this, stated with the estimate: 85%; the middle value sits exactly at the limit.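

The step from compound 3 to compound 4 cannot be read in this assay, because both values are limits: the limit of > 100 ug/mL in this assay, at which 4 of the 4 values shown sit. The compounds shown leave open whether bromo in place of chloro changes growth inhibition at all.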